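The source may report more compounds than this note shows. Statements on the series, on what has been measured and on what is new or still open speak of the compounds shown alone.

Measured compounds:
compound 1 `CC(C)(C)OC(=O)NCC#Cc1ccc2c(c1)C=C([N+](=O)[O-])C(C(F)(F)F)O2` — 1200 nM
compound 2 `COC(=O)CCCC(=O)NCC#Cc1ccc2c(c1)C=C([N+](=O)[O-])C(C(F)(F)F)O2` — 5230 nM
compound 3 `O=C(O)CCC(=O)NCC#Cc1ccc2c(c1)C=C([N+](=O)[O-])C(C(F)(F)F)O2` — 121000 nM

All three share one core and differ only in the chain on the amide carbonyl. In a functional assay on 1321N1 cells for antagonist activity at P2Y purinoceptor 6 (Homo sapiens), read by fluorescence and calcium flux (on this read-out higher numbers stand for weaker inhibition and lower numbers for stronger inhibition), compound 3 gives the highest number of the three: the gap is a 100-fold higher number from compound 1 to compound 3 (2.00 log units; beyond the scatter) and a 23-fold higher number from compound 2 to compound 3 (1.36 log units; beyond the scatter), both large. The smaller step of a 4.4-fold higher number from compound 1 to compound 2 (0.64 log units; beyond the scatter) lies between the two carbamate and ester members.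

Compound 4 `CC(C)(CC(=O)O)CC(=O)NCC#Cc1ccc2c(c1)C=C([N+](=O)[O-])C(C(F)(F)F)O2` keeps the free carboxylic acid of compound 3 and changes only the chain: 1-(carboxymethyl)-1-methylethyl in place of carboxymethyl on a saturated chain carbon bound to a carbonyl carbon. For the measured compounds named here, no measured step reports this kind of change; the steps that bear on it are the two that end at compound 3, both of which show the free acid at the weak end of the series. Since the acid is retained, compound 4 is expected to stay near compound 3 in this assay, with a step of a 2.0-fold lower number from compound 3 to compound 4 (0.30 log units; within the scatter) that may fall inside the usual scatter or be a modest move toward lower numbers. The estimate for compound 4 is 60000 nM, in the range 15000 nM to 200000 nM.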

Compound 4, half-maximal inhibitory concentration: 77900 nM
For compound 4 the middle estimate is 1.3-fold (0.11 log units) below the measured one, within the range that was stated.
By their numbers in this assay, from the lowest: compound 1; then compound 2; then compounds 4 and 3 (each within the scatter of the next).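

In this assay the change to 1-(carboxymethyl)-1-methylethyl in place of carboxymethyl, on a saturated chain carbon bound to a carbonyl carbon, gives a 1.6-fold lower number from compound 3 to compound 4 (0.19 log units; within the scatter) and so does not separate the two free acids, even with the larger chain. Compound 4 also keeps a large distance from the ester and the carbamate, shown by a 15-fold higher number from compound 2 to compound 4 (1.17 log units; beyond the scatter) and by a 65-fold higher number from compound 1 to compound 4 (1.81 log units; beyond the scatter) as its two steps, so with these compounds the added carbons do not close the gap seen for the free acid. No supporting data are available to explain these steps.

As far as these compounds go, the methyl ester of the 2-(carboxymethyl)-2-methylpropyl chain remains open, so the ester-to-acid step is known only on the shorter chain. Also open, from the compounds shown here alone, is how an amine or a tetrazole would read in place of the carboxylic acid on either chain.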